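The source may hold more compounds than are shown below. What is called first, only, known or untested is meant among the compounds shown, and "the series" means these compounds.

Measured so far in an ADME assay on GES1 cells (Homo sapiens) for cytotoxicity, read by MTT assay, with a stated time of 24 h; on this read-out lower numbers stand for higher toxicity in this test and higher numbers for lower toxicity in this test:
Compound 1 `Cc1ccccc1-n1cc(-c2cccc(NS(=O)(=O)c3c[nH]c(=O)[nH]c3=O)c2)nn1`: 21500 nM
Compound 2 `Cc1ccc(-n2cc(-c3cccc(NS(=O)(=O)c4c[nH]c(=O)[nH]c4=O)c3)nn2)cc1`: 15800 nM

Going by the values given here, compound 2 gives the lowest of the two numbers so far in this assay; its nearest neighbour is compound 1, and the step from compound 1 to compound 2 was a 1.4-fold lower number from compound 1 to compound 2 (0.13 log units; within the scatter), so the two compounds cannot be told apart on these data. The next compound, compound 3 `O=c1[nH]cc(S(=O)(=O)Nc2cccc(-c3cn(-c4ccccc4F)nn3)c2)c(=O)[nH]1`, differs from compound 2 in one place: 2-fluorophenyl in place of 4-methylphenyl on an aromatic nitrogen. Among the compounds with values here, only one measured step bears on this change, the exchange of one substituted phenyl for another on the same aromatic nitrogen from compound 1 to compound 2, which was a 1.4-fold lower number from compound 1 to compound 2 (0.13 log units; within the scatter). On that basis no step beyond the scatter is expected in this assay. Compound 3 is therefore estimated at 18000 nM, with a range from 8000 nM to 40000 nM. This estimate means an expected step of a 1.1-fold higher number from compound 2 to compound 3 (0.06 log units; within the scatter).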

Compound 3, half-maximal cytotoxic concentration: "not toxic" (no number reported)
The entry for compound 3 holds no number; the estimate stays without a comparison.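

In this assay, going by these compounds alone, compound 3 is entered only as "not toxic", without a number, so no step from compound 2 to compound 3 can be read. Nothing given here bears on this result. The compounds shown leave open how 2-fluorophenyl compares numerically with 4-methylphenyl on this read-out.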